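The compounds below may be only part of what the source reports. "The series", "measured", "known", "first", "only" and "open" are said of these compounds alone.

Measured compounds in a functional assay on SW480 cells (Homo sapiens) for antiproliferative activity, read by MTT assay, with a stated time of 48 h; a higher number here means a weaker inhibitor, a lower number a stronger inhibitor:

- compound 1, `CC(C)=CCC[C@@]1(C)CC=C(CF)c2oc(C)cc2[C@@H]1/C=C/OC(=O)C=C(C)C`, gives 20000 nM
- compound 2, `CC(C)=CCC[C@@]1(C)CC=C(COC(=O)CCC(=O)O)c2oc(C)cc2[C@@H]1/C=C/OC(=O)C=C(C)C`, gives only a limit of > 40000 nM
- compound 3, `CC(C)=CCC[C@@]1(C)CC=C(CF)c2nnc(C)cc2[C@@H]1/C=C/OC(=O)C=C(C)C`, gives 18200 nM

Compound 3 and compound 1 sit within the usual scatter of each other, so nothing separates the two numbers in this assay; the value of compound 2 is a limit rather than a number, (the limit of > 40000 nM in this assay, at which 1 of the 3 values shown sits).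

Compound 4, `CC(C)=CCC[C@@]1(C)CC=C(COC(=O)CCC(=O)O)c2nnc(C)cc2[C@@H]1/C=C/OC(=O)C=C(C)C`, is compound 3 with one change: ((2-carboxyethyl)carbonyl)oxy in place of fluoro on a saturated chain carbon bound to a double-bonded ring carbon. The same exchange has been measured once, on the core of compound 1: there it gave an at least 2.0-fold higher number from compound 1 to compound 2 (0.30 log units; that floor lies within the scatter), ending at the assay limit, so the true size of that step is not known. Carrying this over to compound 3, a rise of at least that size is expected, with a fair chance that this assay again reports only a limit.

Compound 4 is therefore estimated to give 40000 nM, within a range from 20000 nM to 100000 nM. That estimate means an expected step of a 2.2-fold higher number from compound 3 to compound 4 (0.34 log units; beyond the scatter).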

Compound 4, half-maximal inhibitory concentration: > 40000 nM
Compound 4 ended at the assay's limit (the forecaster's own chance of this, stated with the estimate: 60%); the middle value sits exactly at the limit.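

In this assay, ((2-carboxyethyl)carbonyl)oxy in place of fluoro on a saturated chain carbon bound to a double-bonded ring carbon gives an at least 2.1-fold higher number from compound 3 to compound 4 (0.34 log units; beyond the scatter), so on this core even the floor of the step lies beyond the scatter, which the earlier pair did not show. The change has now been read on two different cores, and it raises the number on neither less than this floor allows: the same change on two cores in this assay, an at least 2.0-fold higher number (0.30 log units; that floor lies within the scatter) from compound 1 to compound 2 and an at least 2.1-fold higher number (0.34 log units; beyond the scatter) from compound 3 to compound 4; the limit leaves it open whether they differ Compound 4 joins compound 2 at a limit, which is not a number: the limit of > 40000 nM in this assay, at which 2 of the 4 values shown sit.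

Going by these compounds, how far past that limit compound 2 and compound 4 truly lie stays open, and with it whether the core alters the size of the step. Also open, on these data alone, is whether a hydroxy group or an acetyl ester at this place would give numbers like those of compound 1 and compound 3.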